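This account rests on a few compounds, and the source may have more. Where it says the series, first, only, none or still open, it means among the compounds named here.

Compound 3 `Cn1c(=O)c(=O)n(C2CCCC2)c2nc(N/N=C/c3ccc(F)cc3Cl)ncc21` carries a 2-chloro-4-fluorophenyl group on the carbon double-bonded to nitrogen, and in a functional assay on PC-3 cells (Homo sapiens) for antiproliferative activity, read by MTT assay (a lower number here means a stronger inhibitor, a higher number a weaker inhibitor), compound 3 gives 15200 nM. Among the compounds with values here, that is the lowest of the three numbers so far: compound 1 `Cn1c(=O)c(=O)n(C2CCCC2)c2nc(N/N=C/c3ccccc3)ncc21`, with phenyl on the same carbon, gives 48200 nM, and compound 2 `Cn1c(=O)c(=O)n(C2CCCC2)c2nc(N/N=C/c3ccc(C(F)(F)F)cc3)ncc21`, with 4-(trifluoromethyl)phenyl there, gives 23600 nM. The step of a 3.2-fold lower number from compound 1 to compound 3 (0.50 log units; beyond the scatter) lies beyond the scatter, whereas the step of a 1.6-fold lower number from compound 2 to compound 3 (0.19 log units; within the scatter) does not.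

Compound 4 `Cn1c(=O)c(=O)n(C2CCCC2)c2nc(N/N=C/c3ccccc3F)ncc21` differs from compound 3 by the change (2-fluorophenyl in place of 2-chloro-4-fluorophenyl on a carbon with a double bond to nitrogen). Within the data shown here, the steps that bear on it are those from compound 1 to compound 3 and from compound 2 to compound 3, both modest at most. Among the measured compounds shown here, compound 4 keeps the fluorine of compound 3 and loses the chlorine; no measured pair separates these two halogens. A number between those of compound 1 and compound 3 therefore seems most likely. For compound 4 a small rise is expected, a 1.8-fold higher number from compound 3 to compound 4 (0.27 log units; within the scatter), within the scatter. Compound 4 is estimated at 28000 nM, with a range from 12000 nM to 65000 nM.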

Compound 4, half-maximal inhibitory concentration: 27600 nM
Compound 4: the middle estimate sits 1.0-fold (0.01 log units) above what was measured; the range from low to high includes it.
By their numbers in this assay, from the lowest: compounds 3, 2, 4 and 1 (each within the scatter of the next, the first and the last beyond it).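

In this assay, the 2-fluorophenyl group of compound 4 cannot be told apart from any of the three earlier groups on this carbon: a 1.8-fold higher number from compound 3 to compound 4 (0.26 log units; within the scatter), a 1.2-fold higher number from compound 2 to compound 4 (0.07 log units; within the scatter) and a 1.7-fold lower number from compound 1 to compound 4 (0.24 log units; within the scatter) all stay within the scatter. Fluoro in place of hydrogen on an aromatic carbon therefore gives no step beyond the scatter here, whereas the fuller change to 2-chloro-4-fluorophenyl does, as a 3.2-fold lower number from compound 1 to compound 3 (0.50 log units; beyond the scatter) shows. Nothing measured here explains these differences.

On these data alone, what a 2-chlorophenyl or a 4-fluorophenyl group would give on this carbon remains open, so the separate contributions of the chlorine and the fluorine in compound 3 cannot be assigned. Also open, as far as these compounds go, is how a phenyl ring carrying an amine or a carboxylic acid would compare with these halogenated rings.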